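Nitro in place of ring hydrogen: expectations for compound 4

This account rests on a few compounds, and the source may have more. Where it says the series, first, only, none or still open, it means among the compounds named here.

Compound 3 `CC(=NNC(=S)Nc1ccccc1)c1ccccn1` carries an unsubstituted phenyl on the thiourea nitrogen. Among the compounds with values here, in a functional assay on T98G cells (Homo sapiens) for cytotoxicity, read by MTT assay, with a stated time of 48 h (a lower number here means a stronger inhibitor, a higher number a weaker inhibitor), compound 3 gives 6.8 nM, the lowest of the three numbers measured so far. Its two neighbours both carry iodo on that ring: compound 1 `CC(=NNC(=S)Nc1cccc(I)c1)c1ccccn1` gives 61 nM, and compound 2 `CC(=NNC(=S)Nc1ccc(I)cc1)c1ccccn1` gives 64 nM. Both steps to compound 3 run the same way, a 9.0-fold lower number from compound 1 to compound 3 (0.95 log units; beyond the scatter) and a 9.4-fold lower number from compound 2 to compound 3 (0.97 log units; beyond the scatter), so removing iodo from either position of the ring lowers the number by about the same amount, beyond the scatter.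

Compound 4 `CC(=NNC(=S)Nc1ccc([N+](=O)[O-])cc1)c1ccccn1` differs from compound 3 by nitro in place of hydrogen on an aromatic carbon. Within the data shown here, no nitro analogue has been measured, so the two iodo steps are the only guide; they show that putting a group on this ring, at either position tested, raised the number beyond the scatter. A nitro group need not behave like iodo, so the expectation for compound 4 is a weakening that is smaller and less certain than the iodo steps: an estimated 4.4-fold higher number from compound 3 to compound 4 (0.64 log units; beyond the scatter), giving an expected value of 30 nM for compound 4, within the range 8 nM to 120 nM.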

Compound 4, half-maximal inhibitory concentration: 140 nM
The estimate for compound 4 lay 4.7-fold (0.67 log units) below the measured number; measured number above the stated range.
By their numbers in this assay, from the lowest: compound 3; then compounds 1 and 2 (each within the scatter of the next); then compound 4.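

Nitro at the place para to a large group gives a 21-fold higher number from compound 3 to compound 4 (1.31 log units; beyond the scatter) in this assay and so shows that the rise seen with iodo is not confined to iodo, since two different groups at this place now both give a higher number than hydrogen. The group itself also matters here, as nitro in place of iodo gives a 2.2-fold higher number from compound 2 to compound 4 (0.34 log units; beyond the scatter) and puts the two groups apart, though by a much smaller margin than the one separating either from hydrogen. Nothing available accounts for the rise with either group, and the numbers record only its direction and size.

From the compounds shown here alone, only hydrogen, iodo and nitro have been seen at this place, so it remains open whether a small group such as fluoro, or an amine, a methoxy group or a carboxylic acid, would stay close to compound 3 or rise as iodo and nitro do. Within the data shown here, it is also open how nitro would behave at the ring position that carries iodo in compound 1, where the only comparison so far is between iodo and hydrogen.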